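Dropping the Chloro Substituent from Compound 2

This account rests on a few compounds, and the source may have more. Where it says the series, first, only, none or still open, it means among the compounds named here.

Four compounds share one core: compound 1 `CCc1cccc(NC(=O)CN2CCN(c3ccccn3)CC2)c1`, compound 2 `Cc1cccc(NC(=O)CN2CCN(c3ccc(Cl)cn3)CC2)c1`, compound 3 `O=C(CN1CCN(c2ccc(Cl)cn2)CC1)Nc1cccnc1` and the still unmeasured compound 4 `Cc1cccc(NC(=O)CN2CCN(c3ccccn3)CC2)c1`. In an assay on cells for antagonist activity at D(4) dopamine receptor (Homo sapiens), read by luminescence and beta-arrestin recruitment, with a stated time of 90 min (on this read-out lower numbers stand for stronger inhibition and higher numbers for weaker inhibition), compound 1 gives 370 nM, compound 2 gives 7780 nM and compound 3 gives 23500 nM. Compound 2 thus stands second highest of the three numbers, nearest compound 3 and far from compound 1. Within the data shown here, the only measured step, a 3.0-fold higher number from compound 2 to compound 3 (0.48 log units; beyond the scatter), concerns the amide side and does not bear on the present change. Compound 4 differs from compound 2 by hydrogen in place of chloro on an aromatic carbon. Among the measured compounds shown here, no measured pair isolates this change; compound 1 lacks the chloro but also carries an ethyl, and its number is far lower than that of compound 2, with two changes mixed. A lower number is tentatively expected, a 4.3-fold lower number from compound 2 to compound 4 (0.64 log units; beyond the scatter). Compound 4 is estimated at 1800 nM, within 400 nM to 7000 nM.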

Compound 4, half-maximal inhibitory concentration: 313 nM
Compound 4: the middle estimate sits 5.8-fold (0.76 log units) above what was measured, outside the stated range (below it).
By their numbers in this assay, from the lowest: compounds 4 and 1 (each within the scatter of the next); then compound 2; then compound 3.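

Taking away the chloro at this place, on the carbon two atoms from the ring nitrogen, is a large change in itself, with the amide side held constant (a 25-fold lower number from compound 2 to compound 4 (1.40 log units; beyond the scatter)). The 5-chloropyridin-2-yl group is therefore clearly the poorer of the two on this read-out. With pyridin-2-yl in place, lengthening methyl to ethyl on the amide side makes no difference beyond the scatter (a 1.2-fold lower number from compound 1 to compound 4 (0.07 log units; within the scatter)).

Going by these compounds, whether a fluoro or a methoxy at this place would read like hydrogen or like chloro remains open, as does whether the step holds with pyridin-3-yl on the amide nitrogen. Nothing available gives a reason for the size of this step.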